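Replacing 1-methylpiperidin-4-yl with (morpholin-4-yl)carbonyl

The compounds below may be only part of what the source reports. "The series", "measured", "known", "first", "only" and "open" are said of these compounds alone.

Compound 1 `CC(=O)Nc1ccc(Nc2nc(N)n(-c3ccccn3)n2)cc1` gives 42.1 mL/min/kg
Compound 2 `CN1CCC(c2cccc(Nc3nc(N)n(-c4ccccn4)n3)c2)CC1` gives 174 mL/min/kg

In an in vivo ADME assay on the whole organism for pharmacokinetics, with Rattus norvegicus as the target (a lower number here means slower removal, a higher number faster removal of the compound), compound 2 has the higher of the two numbers (174 mL/min/kg), and the gap down to compound 1 lies beyond the usual scatter. Compound 3 `Nc1nc(Nc2cccc(C(=O)N3CCOCC3)c2)nn1-c1ccccn1` is still unmeasured. It differs from compound 2 as follows: (morpholin-4-yl)carbonyl in place of 1-methylpiperidin-4-yl on an aromatic carbon. In words, (morpholin-4-yl)carbonyl stands in place of 1-methylpiperidin-4-yl on an aromatic carbon. Among the compounds with values here, no measured pair shows this change on its own, so the expectation is uncertain. Within the data shown here, the only other guide is compound 1, which lacks 1-methylpiperidin-4-yl and gives a lower number (42.1 mL/min/kg). The expected change is a fall beyond the scatter (a 2.9-fold lower number from compound 2 to compound 3 (0.46 log units; beyond the scatter)). For compound 3 the estimated clearance is 60 mL/min/kg (expected range 24 mL/min/kg to 130 mL/min/kg).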

Compound 3, clearance: 16.7 mL/min/kg
The estimate for compound 3 lay 3.6-fold (0.56 log units) above the measured number; measured number outside the range, below it.
By their numbers in this assay, from the lowest: compound 3; then compound 1; then compound 2.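

Within the data shown here, on an aromatic carbon meta to a large group, (morpholin-4-yl)carbonyl in place of 1-methylpiperidin-4-yl gives, in this assay, a 10-fold lower number from compound 2 to compound 3 (1.02 log units; beyond the scatter), a large step and the first direct reading of this change. The group held at this position therefore matters greatly for this read-out. No supporting data bear on why the number falls.

This one swap changes the ring and adds the carbonyl together, so the compounds shown cannot say which part accounts for the step. A morpholin-4-yl group without the carbonyl, or a dimethylamide, at this position would separate the two.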